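A few compounds are considered here, and "the series" means these few. Any claim that something is new, unique, unknown or untested is made for them only; others in the source may bear on it.

Measured compounds:
Compound 1 `CCS(=O)(=O)Nc1cccc2c1CCC2c1ncc[nH]1` — in a functional assay on CHO cells for agonist activity at Alpha-1D adrenergic receptor (Homo sapiens), read by FLIPR and calcium flux (on this read-out higher numbers stand for an effect only at larger amounts of compound and lower numbers for an effect already at smaller amounts), compound 1 gives > 10000 nM, which is a limit of the assay and not a number.
Compound 2 `COc1c(C)ccc2c1CCC2c1ncc[nH]1` — in this assay compound 2 gives > 10000 nM, again a limit of the assay.

Compound 1 therefore stands at the limit only: its value is the limit of > 10000 nM in this assay, at which 2 of the 2 values shown sit, so no number for it is known, and nothing puts it above or below compound 2. With no step between two measured compounds shown, there is no measured reference for the size of any change on the shared core.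

Within the data shown here, compound 3 `c1cncc(-c2cccc3c2CCC3c2ncc[nH]2)c1` is the one compound not yet measured. It differs from compound 1 in one place: pyridin-3-yl in place of (ethylsulfonyl)amino on an aromatic carbon. Among the measured compounds shown here, since both compounds measured so far sit at the limit, the step in this assay can only be expected to be small or none beyond the scatter, with an effect at smaller amounts being the less likely outcome. Compound 3 is estimated to give 8000 nM, in a range from 1500 nM to 30000 nM, which means an expected step of an at least 1.2-fold lower number from compound 1 to compound 3 (0.09 log units; that floor lies within the scatter).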

Compound 3, half-maximal effective concentration: > 10000 nM
Compound 3: no number, only a limit; the forecaster's own chance of this, stated with the estimate: 60%; middle value at least 1.2-fold (0.09 log units) from the limit.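

No step can be read from compound 1 to compound 3 in this assay, since both compounds sit at a limit of the assay and not at a number: the limit of > 10000 nM in this assay, at which 3 of the 3 values shown sit.

The compounds shown leave open whether any group on that aromatic carbon of the shared core brings an effect at smaller amounts, and how large such a change would be.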